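Swapping an aromatic ring for isopropyl on the core nitrogen

The source may report more compounds than this note shows. Statements on the series, on what has been measured and on what is new or still open speak of the compounds shown alone.

Two compounds with a shared core were tested in an ADME assay on Huh-7 cells (Homo sapiens) for cytotoxicity; a higher number here means that more compound is tolerated, a lower number that less compound is tolerated. Compound 1 `COc1ccc(-n2cc(CNCCN3CCN(C)CC3)c(-c3ccccc3C)n2)cc1` carries a 4-methoxyphenyl group on one ring nitrogen. In this assay compound 1 gives only a limit, > 20000 nM, and not a number. This limit, (the limit of > 20000 nM in this assay, at which 1 of the 2 values shown sits), is the top of what the assay reports, so compound 1 sits at the tolerated end of what is known here. Compound 2 `CN1CCN(CCNCc2cn(-c3ccc(C(F)(F)F)cc3)nc2-c2ccc(OC(F)(F)F)cc2)CC1`, a different member of the same series, gives 3000 nM in this assay.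

Compound 3 `Cc1ccccc1-c1nn(C(C)C)cc1CNCCN1CCN(C)CC1` has not been measured. It differs from compound 1 by one change, (isopropyl in place of 4-methoxyphenyl on an aromatic nitrogen).

Going by the values given here, no measured step is available for this exact change. The step that the limit leaves unreadable from compound 1 to compound 3 is expected to be small, with no movement beyond the scatter. Compound 3 is therefore expected to give about 30000 nM in this assay, likely between 10000 nM and 100000 nM, and most probably again only a limit.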

Compound 3, half-maximal cytotoxic concentration: > 20000 nM
Compound 3: no number, only a limit; the forecaster's own chance of this, stated with the estimate: 70%; the middle value is on the limit's open side.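

In this assay, compound 1 and compound 3 each give only a limit and not a number, and no step between them can be read because both sit at the same limit: the limit of > 20000 nM in this assay, at which 2 of the 3 values shown sit.

Going by these compounds, whether isopropyl in place of 4-methoxyphenyl changes how much compound is tolerated remains open.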